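Series notes: methoxy to ethoxy step in Vero cell cytotoxicity

The source may hold more compounds than are shown below. What is called first, only, known or untested is meant among the compounds shown, and "the series" means these compounds.

Measured so far in an ADME assay on Vero cells (Chlorocebus sabaeus) for cytotoxicity, read by MTT assay, with a stated time of 72 h; on this read-out lower numbers stand for stronger inhibition and higher numbers for weaker inhibition:
- compound 1 `COc1cccc(-c2csc(NC(=O)c3ccco3)n2)c1`: > 90000 nM, a limit of the assay, not a number
- compound 2 `COc1cccc(-c2csc(NC(=O)c3ccc([N+](=O)[O-])o3)n2)c1`: 58700 nM
- compound 3 `COc1ccc(-c2csc(NC(=O)c3ccc([N+](=O)[O-])o3)n2)cc1`: 63000 nM

Compound 2 and compound 3 give numbers that sit within the scatter of each other, so no order between them is claimed. Compound 1 stands at the limit of > 90000 nM in this assay, at which 1 of the 3 values shown sits. Two steps are measured. Adding nitro in place of hydrogen on an aromatic carbon gives an at least 1.5-fold lower number from compound 1 to compound 2 (0.18 log units; that floor lies within the scatter). Exchanging 4-methoxyphenyl for 3-methoxyphenyl gives a 1.1-fold higher number from compound 2 to compound 3 (0.03 log units; within the scatter).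

Compound 4 `CCOc1cccc(-c2csc(NC(=O)c3ccc([N+](=O)[O-])o3)n2)c1` differs from compound 2 by methyl in place of hydrogen on a saturated chain carbon bound to an oxygen on an aromatic ring. Neither measured step touches this carbon directly; the nearest analogy is the change of the methoxyphenyl part from compound 2 to compound 3, which stayed within the scatter. Within the data shown here, no measured step therefore points to a move in this assay beyond the scatter for compound 4 in either direction.

For compound 4 the expected step is a 1.0-fold higher number from compound 2 to compound 4 (0.01 log units; within the scatter). The estimate for compound 4 in this assay is 60000 nM, with a range from 30000 nM to 110000 nM, and a real chance that only a limit is returned.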

Compound 4, half-maximal inhibitory concentration: > 90000 nM
Compound 4 was reported as a limit; the forecaster's own chance of this, stated with the estimate: 30%; at least 1.5-fold (0.17 log units) between middle value and limit.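

Methyl in place of hydrogen on a saturated chain carbon bound to an oxygen on an aromatic ring gives an at least 1.5-fold higher number from compound 2 to compound 4 (0.18 log units; that floor lies within the scatter); this is a floor rather than a size, so the true step may stay within the scatter or pass beyond it, whereas the earlier change in the methoxyphenyl part gave a plain number, a 1.1-fold higher number from compound 2 to compound 3 (0.03 log units; within the scatter). In this assay compound 4 gives a limit of the assay, not a number, and so joins compound 1 at the end of the readable range: the limit of > 90000 nM in this assay, at which 2 of the 4 values shown sit. Compound 4 carries the nitro group and compound 1 does not, so in these compounds a place at the limit is not tied to the absence of nitro.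

From the compounds shown here alone, how far past the limit compound 4 lies stays open, and with it whether methoxy to ethoxy moves the number beyond the scatter at all. Also open, going by these compounds, is how a longer chain or a terminal amine on this oxygen would read, and whether the same methoxy to ethoxy change would read alike on the 4-methoxyphenyl of compound 3.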